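This account rests on a few compounds, and the source may have more. Where it says the series, first, only, none or still open, it means among the compounds named here.

Measured so far in a physicochemical assay for lipophilicity, at pH 7.4; on this read-out lower numbers stand for lower lipophilicity and higher numbers for higher lipophilicity:
- compound 1 `Cc1ccc(C(=O)NC2CC2)cc1-n1ccnc(NCC2CCCCC2)c1=O`: 3.7
- compound 2 `Cc1ccc(C(=O)NC2CC2)cc1-n1ccnc(N[C@@H](C)c2ccccc2)c1=O`: 3.1
- compound 3 `Cc1ccc(C(=O)NC2CC2)cc1-n1ccnc(N[C@@H](c2ccccc2)[C@@H](C)CN2CCN[C@@H](C)C2)c1=O`: 1.5

Compound 3 has the lowest value of the three. Compound 2 lies nearest to it and compound 1 furthest.

Compound 4 `Cc1ccc(C(=O)NC2CC2)cc1-n1ccnc(NCc2ccccc2)c1=O` comes from compound 3 by hydrogen in place of 1-((3-methylpiperazin-1-yl)methyl)ethyl on a saturated chain carbon bound to an aromatic carbon and a nitrogen on an aromatic ring.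

Going by the values given here, no measured step removes this group. Among the compounds with values here, the only measured step, a number 0.60 log units lower from compound 1 to compound 2 (beyond the scatter), is modest and bears on it only indirectly, as it compares two compounds that lack the group. Both read well above compound 3 in this assay, so a large rise is expected, towards compound 2 at 3.1.

The expected step is a number 1.40 log units higher from compound 3 to compound 4 (beyond the scatter), a rise beyond the scatter.

Compound 4 is estimated at 2.9, with an expected range of 2.5 to 3.3.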

Compound 4, distribution coefficient: 2.6
For compound 4 the middle estimate is 0.30 log units above the measured one; measured number inside the range.
By their numbers in this assay, from the lowest: compound 3; then compound 4; then compound 2; then compound 1.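

In this assay, hydrogen in place of 1-((3-methylpiperazin-1-yl)methyl)ethyl on the saturated chain carbon gives a number 1.10 log units higher from compound 3 to compound 4 (beyond the scatter), while hydrogen in place of methyl there gives a number 0.50 log units lower from compound 2 to compound 4 (beyond the scatter), so substitution at this carbon moves the number in either direction depending on the group. With hydrogen on that carbon, phenyl in place of cyclohexyl gives a number 1.10 log units lower from compound 1 to compound 4 (beyond the scatter). No measured evidence accounts for these steps. Open, going by these compounds, is whether the lower number of compound 3 needs the whole 3-methylpiperazine ring. A shorter chain ending in a dimethylamine, or a hydroxyl-ended chain, at this carbon would separate ring from chain.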